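Replacing a methoxy group with a cyclohexylmethyl amide

The source may report more compounds than this note shows. Statements on the series, on what has been measured and on what is new or still open speak of the compounds shown alone.

Compound 1 `COc1ccc(N2C(=O)N/C(=C\c3ccc(O)cc3)C2=O)cc1` carries a methoxy group on the aromatic ring attached to the shared core. In a functional assay on NCI-H292 cells (Homo sapiens) for antiproliferative activity (on this read-out lower numbers stand for stronger inhibition and higher numbers for weaker inhibition), compound 1 gives only a limit, > 200000 nM, so its true number is not known, and it sits at the limit of > 200000 nM in this assay, at which 1 of the 3 values shown sits. Two related compounds carry an amide instead of the methoxy: compound 2 `O=C(Nc1ccc(Cl)cc1)c1cccc(N2C(=O)N/C(=C\c3ccc(O)cc3)C2=O)c1` gives 125000 nM in this assay, and compound 3 `O=C(NCc1ccccc1)c1cccc(N2C(=O)N/C(=C\c3ccc(O)cc3)C2=O)c1` gives 23500 nM. The change a 5.3-fold lower number from compound 2 to compound 3 (0.73 log units; beyond the scatter) shows that a benzyl group on the amide nitrogen gives a lower number than a 4-chlorophenyl group. Compound 4 `O=C(NCC1CCCCC1)c1ccc(N2C(=O)N/C(=C\c3ccc(O)cc3)C2=O)cc1` differs from compound 1 by (cyclohexylmethyl)carbamoyl in place of methoxy on an aromatic carbon, a (cyclohexylmethyl)carbamoyl in place of methoxy on an aromatic carbon. Among the measured compounds shown here, no measured step matches this change exactly; the step from compound 2 to compound 3 is the closest guide, and compound 4, like compound 3, carries a group on the amide nitrogen that is not a plain aryl ring. Compound 4 is therefore expected to give about 15000 nM, with a range from 4000 nM to 60000 nM. The expected step of an at least 13-fold lower number from compound 1 to compound 4 (1.12 log units; beyond the scatter) points toward a lower number.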

Compound 4, half-maximal inhibitory concentration: > 200000 nM
Compound 4 ended at the assay's limit; the forecaster's own chance of this, stated with the estimate: 10%; at least 13-fold (1.12 log units) between middle value and limit.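

In this assay compound 1 and compound 4 both give only a limit, not a number, so the step between them cannot be read: the limit of > 200000 nM in this assay, at which 2 of the 4 values shown sit.
The compounds shown leave open how the true numbers of compound 1 and compound 4 compare, and whether (cyclohexylmethyl)carbamoyl in place of methoxy changes the read-out at all.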